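Pentyl on Selenium: a Second Look at Growth Inhibition

A few compounds are considered here, and "the series" means these few. Any claim that something is new, unique, unknown or untested is made for them only; others in the source may bear on it.

This account concerns four selenium-bearing compounds tested for their effect on growth. Compound 2 `CSc1ccc(CNc2nc([SeH])nc3ccccc23)cc1` and compound 1 `CCCCC[Se]c1nc(NCc2ccc(SC)cc2)c2ccccc2n1` share one core and differ in a single place: pentyl in place of hydrogen on a selenium. In an ADME assay on BEAS-2B cells (Homo sapiens) for cytotoxicity, read by MTT assay, with a stated time of 72 h (a lower number here means a stronger inhibitor of growth, a higher number a weaker inhibitor of growth), compound 2 gives 410 nM, while compound 1 gives 34700 nM; the change produced an 85-fold higher number from compound 2 to compound 1 (1.93 log units; beyond the scatter).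

Compound 3 `Nc1nc([SeH])nc2ncccc12` belongs to a different core; the difference between the two cores is not broken down here. In this assay compound 3 gives 5890 nM, which stands between the other two measured values.

Compound 4 `CCCCC[Se]c1nc(N)c2cccnc2n1` has not yet been measured. It differs from compound 3 in one place: pentyl in place of hydrogen on a selenium. This is the same change that turns compound 2 into compound 1, made at a place described in identical words, so the step already seen is the natural point of reference. Because the earlier step was an 85-fold higher number from compound 2 to compound 1 (1.93 log units; beyond the scatter), compound 4 is expected to give a markedly higher number than compound 3 in this assay, though the different core leaves room for a smaller shift, and an estimate of a 25-fold higher number from compound 3 to compound 4 (1.41 log units; beyond the scatter) is therefore taken as the expected step. On that basis, compound 4 is estimated to give about 150000 nM in this assay, with the expectation spanning from 40000 nM to 600000 nM.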

Compound 4, concentration for 50% growth inhibition: 16300 nM
Compound 4: middle estimate off by 9.2-fold (0.96 log units), on the high side; the whole stated range lies above it.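

Placing pentyl in place of hydrogen on a selenium of the core of compound 3 gave a 2.8-fold higher number from compound 3 to compound 4 (0.44 log units; beyond the scatter), so in this assay the change moved the number in the same direction on both cores. The size of the step did not carry over, and the gap between the two steps is larger than repeated measurements would explain: the same change on two cores in this assay, an 85-fold higher number (1.93 log units; beyond the scatter) from compound 2 to compound 1 and a 2.8-fold higher number (0.44 log units; beyond the scatter) from compound 3 to compound 4, 31-fold (1.49 log units) apart, beyond the scatter of two such steps With a single pair on each core, this shows that the direction was shared in these four compounds, but it does not show which difference between the cores goes with the smaller step, nor what the change would do on any further core.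

The compounds shown leave open whether the step depends on the chain itself, as a propyl group, an octyl chain or a benzyl group on the selenium would show on each core. They also leave open whether an unsubstituted amine on the core of compound 2, in place of the substituted amine it carries, would bring its pentyl step closer to the smaller one seen on the core of compound 3.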